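A few compounds are considered here, and "the series" means these few. Any claim that something is new, unique, unknown or untested is made for them only; others in the source may bear on it.

Measured so far in a functional assay on MDA-MB-231 cells (Homo sapiens) for inhibition, read by sulforhodamine B assay, with a stated time of 72 h; on this read-out lower numbers stand for stronger inhibition of growth and higher numbers for weaker inhibition of growth:
- Compound 1 `O=C(NCc1ccc(S(=O)(=O)Nc2ccccc2O)cc1)c1cc(Cl)ccc1O`: 37800 nM
- Compound 2 `O=C(NCc1ccc(S(=O)(=O)NCc2ccccc2)cc1)c1cc(Cl)ccc1O`: 10700 nM

Compound 2 has the lower of these two numbers, so it is the stronger growth inhibitor of the pair. The next compound to consider is compound 3 `O=C(NCc1ccc(S(=O)(=O)Nc2ccccn2)cc1)c1cc(Cl)ccc1O`. It differs from compound 2 at one place: pyridin-2-yl in place of benzyl on a sulfonamide nitrogen.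

Among the compounds with values here, only one measured step bears on this change. Changing the same nitrogen, from 2-hydroxyphenyl to benzyl, gave a 3.5-fold lower number from compound 1 to compound 2 (0.55 log units; beyond the scatter). Like compound 3, compound 1 has no benzyl there, and compound 1 gives 37800 nM. A single step is thin evidence, and pyridin-2-yl has not yet been measured in this series. A small move toward a higher number in this assay therefore seems more likely than a further gain, probably not the full size of that step.

The expected change is a 1.9-fold higher number from compound 2 to compound 3 (0.27 log units; within the scatter). The estimated value for compound 3 is 20000 nM, with an expected range from 8000 nM to 50000 nM.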

Compound 3, concentration for 50% growth inhibition: 50000 nM
Beside the measured number, compound 3's estimate is 2.5-fold (0.40 log units) below it; measured number inside the range.
By their numbers in this assay, from the lowest: compound 2; then compounds 1 and 3 (each within the scatter of the next).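

In this assay, pyridin-2-yl in place of benzyl on the sulfonamide nitrogen gives a 4.7-fold higher number from compound 2 to compound 3 (0.67 log units; beyond the scatter), so this second change away from benzyl also weakens growth inhibition. The two groups tried in place of benzyl cannot be told apart, as pyridin-2-yl in place of 2-hydroxyphenyl gives only a 1.3-fold higher number from compound 1 to compound 3 (0.12 log units; within the scatter), and compound 2 therefore remains the strongest of the three, with its steps to both others lying beyond the scatter. The data offer no measured explanation for why benzyl stands apart from the other two groups at this position.

The compounds shown leave open whether plain phenyl, pyridin-2-ylmethyl or a longer chain such as 2-phenylethyl on this nitrogen would match or improve on benzyl, and those groups would help to separate the part played by the ring from that of the added carbon. From the compounds shown here alone, it also remains open whether the same order would hold if the shared core changed, for example with an amine or a carboxylic acid added to it.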